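The source may hold more compounds than are shown below. What is called first, only, known or untested is meant among the compounds shown, and "the series" means these compounds.

The measured compounds:
Compound 1, `COc1ccc(-c2c(C)nc3c(N4CC[C@@H](NC(C)=O)C4)cc(C)nn23)cn1`, gives > 95% in an ADME assay on microsomes from liver (Mus musculus) for metabolic stability, read by LC-MS, with NADPH named in the record, with a stated time of 60 min, tested at 1 uM, in the absence of a further agent (a lower number here means that less of the compound is left, a higher number that more of the compound is left), a limit of the assay rather than a number.
Compound 2, `COc1ccc(-c2c(C)nc3c(N4CC[C@@H](NC(C)=O)C4)cc(Cl)nn23)cc1OC`, gives > 95% in this assay, again a limit.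
Compound 3, `CCCCCC(=O)N[C@@H]1CCN(c2cc(C)nn3c(-c4ccc(OC)c(OC)c4)c(C)nc23)C1`, gives > 95% in this assay, also a limit.

Compound 3 thus stands at the ceiling of what this assay reports, the position at which every value shown sits (the limit of > 95% in this assay, at which 3 of the 3 values shown sit). Compound 4, `COc1ccc(-c2c(C)nc3c(N4CC[C@@H](NS(=O)(=O)c5ccc(Cl)cc5)C4)cc(C)nn23)cc1OC`, differs from compound 3 in one place: (4-chlorophenyl)sulfonyl in place of pentylcarbonyl on an amine nitrogen. Within the data shown here, no measured pair isolates this change, so there is no measured step to lean on. Because all values shown rest at the limit (the limit of > 95% in this assay, at which 3 of the 3 values shown sit), the step from compound 3 to compound 4 is expected to stay within the usual scatter, in either direction. Compound 4 is therefore estimated at 92%, ranging from 78% to 100%. The expected step is a number at least 3 percentage points lower from compound 3 to compound 4 (that floor lies within the scatter).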

Compound 4, percent of the compound remaining: > 95%
Compound 4: a limit, no number; the forecaster's own chance of this, stated with the estimate: 60%; middle value at least 3 percentage points away from the limit.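

No step can be read between compound 3 and compound 4, as both give only a limit in this assay: the limit of > 95% in this assay, at which 4 of the 4 values shown sit. The compounds shown leave open whether (4-chlorophenyl)sulfonyl in place of pentylcarbonyl changes how much compound remains.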